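Adding a methoxybenzyl group to a bare pyrazole nitrogen

The source may report more compounds than this note shows. Statements on the series, on what has been measured and on what is new or still open speak of the compounds shown alone.

Compound 3 `CN1CCN(c2ccc(NC(=N)c3cc4c(-c5ccccc5)n[nH]c4cn3)cc2)CC1` has no reported number in an ADME assay on AG1523 cells (Homo sapiens) for cytotoxicity, read by MTT assay, with a stated time of 72 h (on this read-out higher numbers stand for weaker inhibition and lower numbers for stronger inhibition), its entry reading "not determined" (no result reported); the same is true of compound 1 `COc1ccc(Cn2ncc3cc(C(=N)Nc4ccc(N5CCN(C)CC5)cc4)ncc32)cc1`, whose entry reads "not determined" (no result reported), so compound 3 stands nowhere on the measured scale. Going by the values given here, the one compound with a result is compound 2 `COc1ccc(Cn2nc(-c3ccccc3)c3cc(C(=N)Nc4ccc(N5CCN(C)CC5)cc4)nc(NC4CCCCC4)c32)cc1`, which in this assay gives 3330 nM. Compound 4 `COc1ccc(Cn2nc(-c3ccccc3)c3cc(C(=N)Nc4ccc(N5CCN(C)CC5)cc4)ncc32)cc1` is built from compound 3 by the change (4-methoxybenzyl in place of hydrogen on an aromatic nitrogen). Among the compounds with values here, no measured pair shows what this change alone does in this assay, so the direction and size of the step cannot be taken from the data. Compound 2 gives 3330 nM in this assay and differs from compound 4 only by carrying a cyclohexylamino group. On that basis compound 4 is expected to give about 3000 nM in this assay, in an estimated range from 1000 nM to 10000 nM.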

Compound 4, half-maximal inhibitory concentration: 10200 nM
Estimate against measurement, compound 4: 3.4-fold (0.53 log units) below, outside the stated range (above it).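

In this assay, going by these compounds alone, the one step that can be read is a 3.1-fold higher number from compound 2 to compound 4 (0.49 log units; beyond the scatter) as hydrogen takes the place of cyclohexylamino on an aromatic carbon, so with 4-methoxybenzyl present, losing cyclohexylamino goes with weaker inhibition. Compound 3 has no number, so the step that adds 4-methoxybenzyl cannot be read. Nothing measured here gives a cause for the step. Still open, as far as these compounds go, is what a methyl group on that aromatic nitrogen would give, and what a plain amino group would give in place of cyclohexylamino.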